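Cyclopentane sulfone amides: trimming the second amide

The source may report more compounds than this note shows. Statements on the series, on what has been measured and on what is new or still open speak of the compounds shown alone.

Of the compounds shown here, two carry numbers so far. Compound 1 `N#CCNC(=O)[C@@H]1C[C@@H](S(=O)(=O)c2ccccc2C(F)(F)F)C[C@H]1C(=O)N1CCOCC1` gives 2 nM in a functional assay on A20 cells (Mus musculus) for inhibition, with stated times of 1 h, 16 h and 24 h; a higher number here means a weaker inhibitor, a lower number a stronger inhibitor. Compound 2 `N#CC1(NC(=O)[C@@H]2C[C@@H](S(=O)(=O)c3ccccc3)C[C@H]2C(=O)N2CCCCC2)CC1` gives 5 nM in this assay, the higher of the two numbers, and its gap to compound 1 lies beyond the usual scatter. Compound 3 `CN(C)C(=O)[C@@H]1C[C@H](S(=O)(=O)c2ccccc2)C[C@H]1C(=O)NC1(C#N)CC1` is not yet measured. It differs from compound 2 in one place: dimethylamino in place of piperidin-1-yl on a carbonyl carbon. Among the compounds with values here, no pair of measured compounds differing in only one place is available, so the size of this step cannot be read from the data; it rests on expectation alone. Exchanging a ring amine for an open, smaller one at this carbonyl is expected to cost a modest amount, the step of a 2.0-fold higher number from compound 2 to compound 3 (0.30 log units; within the scatter) pointing toward a higher number while staying within the order of the usual scatter. Compound 3 is therefore expected to give 10 nM, with a range from 3 nM to 40 nM.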

Compound 3, half-maximal inhibitory concentration: 91 nM
Estimate against measurement, compound 3: 9.1-fold (0.96 log units) below; the measured number lies above the stated range.
By their numbers in this assay, from the lowest: compound 1; then compound 2; then compound 3.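

In this assay, dimethylamino in place of piperidin-1-yl on a carbonyl carbon gives an 18-fold higher number from compound 2 to compound 3 (1.26 log units; beyond the scatter) and so marks this second amide as a place where the choice of amine matters strongly. The earlier compounds shown here gave no step at this position, and this single pair now shows that the open amine is not a neutral replacement for the ring amine. Nothing measured here accounts for the magnitude of this step.

From the compounds shown here alone, it remains open whether the ring itself or the number of carbons on the amide nitrogen carries the difference: pyrrolidin-1-yl and diethylamino on the same carbonyl, with the rest of compound 2 kept, would help separate the two. Going by these compounds, it is also open whether the same exchange costs as much when the cyanomethyl amide and trifluoromethyl-bearing phenyl sulfone of compound 1 are present.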